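This account rests on a few compounds, and the source may have more. Where it says the series, first, only, none or still open, it means among the compounds named here.

Measured so far:
- compound 1 `O=C(N[C@H]1CN(S(=O)(=O)c2ccccc2)C[C@@H]1C(=O)N[C@H]1CCCNC1)c1cc(-c2ccccc2Cl)on1`: 0.31 10^-6 cm/s
- compound 2 `CN(C(=O)c1cc(-c2ccccc2Cl)on1)[C@H]1CN(S(=O)(=O)c2ccccc2)C[C@@H]1C(=O)N[C@H]1CCCNC1`: 0.06 10^-6 cm/s

In an ADME assay on Caco-2 cells (Homo sapiens) for permeability, in the apical to basolateral direction, at pH 7.4 (a lower number here means that the compound crosses the layer more slowly, a higher number that the compound crosses the layer faster), compound 1 has the higher of the two numbers, 0.31 10^-6 cm/s. For the measured compounds named here, the only measured step is a 5.2-fold lower number from compound 1 to compound 2 (0.71 log units; beyond the scatter), and it comes from a methyl in place of hydrogen on an amide-type nitrogen.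

Compound 3 `CN1CCC[C@H](NC(=O)[C@H]2CN(S(=O)(=O)c3ccccc3)C[C@@H]2NC(=O)c2cc(-c3ccccc3Cl)on2)C1` has not yet been measured. It also gains a methyl on compound 1, but at a different nitrogen: methyl in place of hydrogen on an amine nitrogen in a ring. Put simply, piperidin-3-yl becomes 1-methylpiperidin-3-yl.

Going by the values given here, the one step that bears on this change is the move to compound 2, a 5.2-fold lower number from compound 1 to compound 2 (0.71 log units; beyond the scatter). It is a guide of limited use, since that methyl sits on an amide-type nitrogen and not on an amine nitrogen in a ring. Among the compounds with values here, no measured pair shows the change made in compound 3. In this assay, no step beyond the scatter is therefore expected, although a drop cannot be ruled out, and the expected step is a 1.0-fold lower number from compound 1 to compound 3 (0.01 log units; within the scatter). For compound 3 the estimated value is 0.3 10^-6 cm/s, with an expected range from 0.08 10^-6 cm/s to 1 10^-6 cm/s.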

Compound 3, apparent permeability: 1.3 10^-6 cm/s
Beside the measured number, compound 3's estimate is 4.3-fold (0.64 log units) below it; measured number above the stated range.
By their numbers in this assay, from the lowest: compound 2; then compound 1; then compound 3.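

At the amine nitrogen in the six-membered ring, methyl in place of hydrogen brings a 4.2-fold higher number from compound 1 to compound 3 (0.62 log units; beyond the scatter) in this assay, so a single added carbon at this position can raise the number rather than lower it. Set against a 5.2-fold lower number from compound 1 to compound 2 (0.71 log units; beyond the scatter), the same methyl gives steps in opposite directions at the two nitrogens, and among these three compounds the step at the amide-type nitrogen gives no guide to the step at the ring nitrogen. Nothing available here explains why the number rises at the ring nitrogen or falls at the amide-type nitrogen.

The compounds shown leave open whether the rise belongs to methyl alone or would carry on with an ethyl group or a longer chain on the same ring nitrogen, and what an acetyl group there, which places a carbonyl on that nitrogen, would do to the number. They also leave open whether the two methyl steps would hold if both nitrogens carried a methyl in one compound, so that the gain at the ring nitrogen and the loss at the amide-type nitrogen could be weighed together.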